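The source may hold more compounds than are shown below. What is called first, only, known or untested is meant among the compounds shown, and "the series" means these compounds.

Measured so far in an ADME assay on a cell-free system (plasma, Homo sapiens) for metabolic stability, read by LC-MS, with a stated time of 60 min, at 37 degrees C, tested at 50 uM; a lower number here means that less of the compound is left, a higher number that more of the compound is left:
- compound 1 `C[C@@H](O)[C@H]1C(=O)N2C(C(=O)OCOC(=O)C3CCCCC3)=C(S[C@@H]3CN[C@H](C(=O)Nc4cccc(C(=O)O)c4)C3)[C@H](C)[C@H]12` gives 20%
- compound 2 `CC(C)OC(=O)OCOC(=O)C1=C(S[C@@H]2CN[C@H](C(=O)Nc3cccc(C(=O)O)c3)C2)[C@H](C)[C@@H]2[C@@H]([C@@H](C)O)C(=O)N12` gives 62%

Compound 2 stands highest of the two measured numbers; its nearest neighbour is compound 1, reached by the step of a number 42 percentage points higher from compound 1 to compound 2 (beyond the scatter), which corresponds to isopropoxy in place of cyclohexyl on a carbonyl carbon.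

The next compound, compound 3 `CC(C)OC(=O)OCOC(=O)C1=C(S[C@@H]2CN[C@H](C(=O)Nc3cccc(C(=O)OCOC(=O)OC(C)C)c3)C2)[C@H](C)[C@@H]2[C@@H]([C@@H](C)O)C(=O)N12`, differs from compound 2 at a different place: ((isopropoxycarbonyl)oxy)methyl in place of hydrogen on an oxygen next to a carbonyl group. The shared core and the isopropoxy ester part of compound 2 are kept unchanged.

Among the measured compounds shown here, no measured step bears directly on this change. For the measured compounds named here, the only step available, from compound 1 to compound 2, alters a group on the carbonyl carbon of the other ester and says nothing about adding a group on the oxygen of the carboxylic acid. The estimate therefore rests mainly on the value of compound 2 in this assay, with a wide range to cover both directions. For compound 3 a downward step is estimated, a number 17 percentage points lower from compound 2 to compound 3 (beyond the scatter), of a size that may not clear the scatter. Compound 3 is expected to give about 45% in this assay, with a range from 20% to 70%.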

Compound 3, percent of the compound remaining: 28%
Estimate against measurement, compound 3: 17 percentage points above; the measured number falls inside the stated range.
By their numbers in this assay, from the lowest: compounds 1 and 3 (each within the scatter of the next); then compound 2.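

The carboxylic acid end of compound 2 is a place where this assay responds strongly: hydroxy to ((isopropoxycarbonyl)oxy)methoxy comes with a number 34 percentage points lower from compound 2 to compound 3 (beyond the scatter). Among the compounds shown here, until now the only step, a number 42 percentage points higher from compound 1 to compound 2 (beyond the scatter), lay on a carbonyl carbon of the other ester, so the number is now seen to move at a second, separate place on the shared core. The isopropoxy unit also reads differently here: it stands with the higher number in the earlier step, whereas the ((isopropoxycarbonyl)oxy)methyl group that contains it stands with the lower number in this one, and no supporting measurement accompanies this result to explain the fall.

As far as these compounds go, it remains open whether the size of the entering group matters on this oxygen, as a methyl ester or an ethyl ester there would show, or whether any group in place of hydrogen gives a similar step. An amide at the same carbonyl, or a cyclohexyl-bearing version of the ((isopropoxycarbonyl)oxy)methyl group, would also test how far the fall depends on the ester link and on the isopropoxy end of the group.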